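A few compounds are considered here, and "the series" means these few. Any claim that something is new, unique, unknown or untested is made for them only; others in the source may bear on it.

The series shares one core, seen in compound 1 `Nc1scc(CN2CCN(c3ccccc3C(F)(F)F)CC2)c1C(=O)c1ccc(Cl)cc1`, compound 2 `Nc1scc(CN2CCN(c3ccncc3)CC2)c1C(=O)c1ccc(Cl)cc1` and compound 3 `Nc1scc(CN2CCN(c3cccc4ccccc34)CC2)c1C(=O)c1ccc(Cl)cc1`; the three differ only in the group carried on the amine nitrogen in the ring. In an assay on CHO cells for displacement of a labelled ligand from adenosine receptor A3 (Homo sapiens), read by scintillation counting, with a stated time of 120 min, tested at 10 uM (a lower number here means less inhibition, a higher number more inhibition at the concentration tested (going by the name of the read-out)), compound 1 gives 0%. Compound 2 gives 2% in this assay. Compound 3 gives 0% in this assay, level with compound 1 at the digits shown and together with it the lowest of the three numbers. The step of no change at the digits printed from compound 1 to compound 3 (within the scatter) and the step of a number 2 percentage points lower from compound 2 to compound 3 (within the scatter) are both within the scatter, as is a number 2 percentage points higher from compound 1 to compound 2 (within the scatter); none of the three exchanges at this position produced measurable inhibition.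

Compound 4 `Nc1scc(CN2CCN(c3c(Cl)cccc3Cl)CC2)c1C(=O)c1ccc(Cl)cc1` continues with a change at the same place: 2,6-dichlorophenyl in place of naphthalen-1-yl on an amine nitrogen in a ring. Among the measured compounds shown here, the steps that bear on it are the three exchanges already measured, none of which moved the number beyond the scatter, so no step beyond the scatter is expected in this assay in either direction. The expected step is a number 1 percentage points higher from compound 3 to compound 4 (within the scatter). For compound 4 the estimated value is 1%, with an expected range from -6% to 8%.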

Compound 4, a percentage reported as inhibition, at one concentration (the size of the read-out at that concentration, not a potency): 1%
For compound 4 middle estimate and measured number coincide at the digits printed; the range from low to high includes it.
By their numbers in this assay, from the lowest: compounds 1, 3, 4 and 2 (each within the scatter of the next).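

The 2,6-dichlorophenyl group makes a fourth group on the amine nitrogen in the ring that leaves the number in this assay within the scatter of all the others: against naphthalen-1-yl (a number 1 percentage points higher from compound 3 to compound 4 (within the scatter)), against pyridin-4-yl (a number 1 percentage points lower from compound 2 to compound 4 (within the scatter)) and against 2-(trifluoromethyl)phenyl (a number 1 percentage points higher from compound 1 to compound 4 (within the scatter)). Across these four compounds, neither two chlorine atoms on the ring nor one aromatic ring in place of two separates the numbers. No measured evidence bears on this result.

As far as these compounds go, all four groups at this position are aromatic rings, so it remains open whether a benzyl group, an acetyl group or a longer alkyl chain on this nitrogen would give a number beyond the scatter. Also open, from the compounds shown here alone, is whether a methoxy group in place of the chlorine of the shared core would do so.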